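The compounds below may be only part of what the source reports. "The series", "measured", "known", "first", "only" and "open" are said of these compounds alone.

Measured so far in a functional assay on PC-3 cells (Homo sapiens) for inhibition, read by sulforhodamine B assay, with a stated time of 72 h (a lower number here means a stronger inhibitor, a higher number a weaker inhibitor), for the series:
compound 1 `Nc1sc(-c2ccc(Cl)cc2)c(-c2ccc(Cl)cc2)c1C(=O)NC1CCC1` gives 24800 nM
compound 2 `CCCCNC(=O)c1c(N)sc(-c2ccc(Cl)cc2)c1-c1ccc(Cl)cc1` gives 17800 nM
compound 3 `CC(C)CNC(=O)c1c(N)sc(-c2ccc(Cl)cc2)c1-c1ccc(Cl)cc1` gives 13200 nM

Compound 3 stands at 13200 nM and cannot be separated from the other two compounds. The measured steps are a 1.3-fold lower number from compound 2 to compound 3 (0.13 log units; within the scatter) and a 1.9-fold lower number from compound 1 to compound 3 (0.27 log units; within the scatter), and both lie within the scatter. The remaining step, a 1.4-fold lower number from compound 1 to compound 2 (0.14 log units; within the scatter), also lies within the scatter. Exchange among cyclobutyl, butyl and isobutyl on the amide-type nitrogen has therefore produced no resolved change in these three compounds.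

Compound 4 `COc1ccc(CNC(=O)c2c(N)sc(-c3ccc(Cl)cc3)c2-c2ccc(Cl)cc2)cc1` has not yet been measured. The change from compound 3 is 4-methoxyphenyl in place of isopropyl on a saturated chain carbon bound to an amide-type nitrogen and can also be read as isobutyl to 4-methoxybenzyl. These three steps bear on it only indirectly, since all of them exchange saturated groups and none brings an aromatic ring onto this chain. They give no direction for the new group. A step beyond the scatter is not expected in this assay, although the untested group calls for a wide range.

The expected change is a 1.1-fold lower number from compound 3 to compound 4 (0.04 log units; within the scatter), which is an estimate close to no change. Compound 4 is expected at 12000 nM, with an estimated range from 4500 nM to 30000 nM.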

Compound 4, half-maximal inhibitory concentration: 29500 nM
Beside the measured number, compound 4's estimate is 2.5-fold (0.39 log units) below it, within the range that was stated.
By their numbers in this assay, from the lowest: compounds 3, 2, 1 and 4 (each within the scatter of the next, the first and the last beyond it).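

In this assay, within the data shown here, the exchange of isobutyl for 4-methoxybenzyl on the amide-type nitrogen gives the first resolved step, a 2.2-fold higher number from compound 3 to compound 4 (0.35 log units; beyond the scatter) and so a weaker inhibitor, showing that this position does not accept every group alike. The separation holds against isobutyl alone, since a 1.7-fold higher number from compound 2 to compound 4 (0.22 log units; within the scatter) and a 1.2-fold higher number from compound 1 to compound 4 (0.08 log units; within the scatter) both stay within the scatter, so compound 4 cannot be set apart from the butyl and cyclobutyl amides and no general penalty for an aromatic ring on this chain can be claimed. The step also brings in a six-membered aromatic ring and a methoxy oxygen together, and no measurement at hand bears on why the number rises.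

The compounds shown leave open whether the ring or its methoxy group carries the step, a question that an unsubstituted benzyl on the same nitrogen could address. They also leave open whether a group of another kind at this position, such as a dimethylaminoethyl chain with its tertiary amine or a carboxylic acid on a short chain, would move the number beyond the scatter in either direction.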